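The compounds below may be only part of what the source reports. "The series", "measured", "known", "first", "only" and "open" are said of these compounds alone.

Compound 1, `Cc1nc2c(OCc3ccccc3)cccn2c1CN`, gives 46% in a functional assay on the whole organism with Rattus norvegicus as the target, at a dose of 40 mg/kg by the intraperitoneal route; a lower number here means less inhibition, a higher number more inhibition at the dose given (going by the name of the read-out).
Compound 2, `Cc1nc2c(OCc3ccccc3)cccn2c1/N=C/N(C)C`, gives 64% in this assay.
Compound 3, `CNC(=O)Nc1c(C)nc2c(OCc3ccccc3)cccn12`, gives 22% in this assay.

All three compounds share the same core and differ only in the group attached to one aromatic carbon. Compound 3 stands lowest of the three in this assay: the gap is a number 24 percentage points lower from compound 1 to compound 3 (beyond the scatter), and the gap to compound 2 is larger still, a number 42 percentage points lower from compound 2 to compound 3 (beyond the scatter), both beyond the scatter of repeated measurements.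

Compound 4, `CCCNc1c(C)nc2c(OCc3ccccc3)cccn12`, has not yet been measured in this assay. It differs from compound 3 in one place: propyl in place of methylcarbamoyl on a nitrogen on an aromatic ring. The urea is thus cut back to a plain chain on the ring nitrogen, and both hydrogen-bond partners of the methylcarbamoyl group are lost.

Among the measured compounds shown here, no measured step removes a carbonyl-bearing group in this way, so the comparison is indirect. What the measured steps show is that installing the (methylcarbamoyl)amino group lowered inhibition both from compound 1 and from compound 2, so its removal is expected to move the number upward rather than downward, though only modestly, since propylamino is not the same as either of those groups. The expected step is a number 16 percentage points higher from compound 3 to compound 4 (beyond the scatter).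

For compound 4 the estimate in this assay is therefore 38%, with a range from 18% to 58%.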

Compound 4, a percentage reported as inhibition, in the whole organism at one dose (the size of the read-out at that dose, not a potency): 99%
For compound 4 the middle estimate is 61 percentage points below the measured one; measured number outside the range, above it.
By their numbers in this assay, from the lowest: compound 3; then compound 1; then compound 2; then compound 4.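

In this assay the group on this aromatic carbon proves able to move the read-out much further than the first three compounds showed: propyl in place of methylcarbamoyl on a nitrogen on an aromatic ring gives a number 77 percentage points higher from compound 3 to compound 4 (beyond the scatter). The entering propyl has no ring and no hydrogen-bond donors or acceptors, yet compound 4 also stands clearly above the other two compounds, with a number 35 percentage points higher from compound 2 to compound 4 (beyond the scatter) and a number 53 percentage points higher from compound 1 to compound 4 (beyond the scatter), so neither the carbonyl nor the extra nitrogen of the earlier groups is needed for a high number at this dose. Nothing measured here explains why propylamino stands so far above the other groups.

The compounds shown leave open whether this high number belongs to propyl in particular or to plain chains in general, which a shorter ethyl chain, a longer butyl chain or a cyclopropylmethyl group on the same nitrogen would help to separate. The unsubstituted amine is also missing from the set, and a read-out at one dose gives no measure of potency for any of these compounds.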